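The source may report more compounds than this note shows. Statements on the series, on what has been measured and on what is new or still open speak of the compounds shown alone.

Notes on the series: in a functional assay on brain (Rattus norvegicus, strain Wistar) for inhibition (a lower number here means a stronger inhibitor, a higher number a weaker inhibitor), compound 1 `CCCCCOc1ccc(-c2c(C)[nH]c(=O)n2C2CCCCC2)cc1` gives 9100 nM, compound 2 `Cc1[nH]c(=O)n(C2CCCCC2)c1-c1ccc(OCCC(C)C)cc1` gives 7200 nM and compound 3 `CCCCCCCCCCOc1ccc(-c2c(C)[nH]c(=O)n2C2CCCCC2)cc1` gives 10500 nM. Compound 3 stands level with the other two, as the steps to it show: a 1.2-fold higher number from compound 1 to compound 3 (0.06 log units; within the scatter) and a 1.5-fold higher number from compound 2 to compound 3 (0.16 log units; within the scatter).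

The next structure is compound 4 `Cc1[nH]c(=O)n(C2CCCCC2)c1-c1ccc(Oc2ccccc2)cc1`, which has phenyl in place of decyl on an oxygen on an aromatic ring. Only the chain steps bear on this change. Along with the two above, there is a 1.3-fold lower number from compound 1 to compound 2 (0.10 log units; within the scatter). Among these three compounds, the group on the oxygen varies with no step beyond the scatter, and none of them goes against this. However, none of them carries a ring on that oxygen, so the data do not test the change directly.

The flat chain steps give no reason to expect a shift in this assay, although the untested ring calls for a wider range than the scatter alone. The expected step is a 1.2-fold lower number from compound 3 to compound 4 (0.07 log units; within the scatter), so no change beyond the scatter is expected. The estimated value for compound 4 is 9000 nM, with an expected range of 3000 nM to 30000 nM.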

Compound 4, half-maximal inhibitory concentration: 7900 nM
Compound 4: the middle estimate sits 1.1-fold (0.06 log units) above what was measured, and the stated range covers the measured number.
By their numbers in this assay, from the lowest: compounds 2, 4, 1 and 3 (each within the scatter of the next).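

In this assay, a ring on this oxygen behaves as the saturated chains did: phenyl in place of decyl gives no shift beyond the scatter (a 1.3-fold lower number from compound 3 to compound 4 (0.12 log units; within the scatter)), and the same holds with isopentyl (a 1.1-fold higher number from compound 2 to compound 4 (0.04 log units; within the scatter)) and pentyl (a 1.2-fold lower number from compound 1 to compound 4 (0.06 log units; within the scatter)) as the group that leaves. Within the data shown here, compound 4 therefore extends the flat picture from open chains to one six-membered aromatic ring of carbon only, which the chain steps alone could not test, and no compound here goes against it. No measurement in hand explains why the number stays level across these groups on the oxygen.

What the level numbers leave open is whether any group on this oxygen can move the reading, for instance a phenyl carrying a carboxylic acid or an amine, or a benzyl group with its ring set one carbon away from the oxygen. The cyclohexyl and methyl groups on the shared core are the same in all of these compounds, so the part they play in this assay remains unknown, as does whether a different group at either place would make the oxygen substituent matter.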